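Pyridyl in place of sulfonamidophenyl on the shared core

This account rests on a few compounds, and the source may have more. Where it says the series, first, only, none or still open, it means among the compounds named here.

Compound 1 `C[C@@H](O[C@H]1CN2C(=O)C=C(c3ccccc3)CC2[C@@H]1c1ccc(F)cc1)c1cc(C(F)(F)F)cc(C(F)(F)F)c1` and compound 2 `C[C@@H](O[C@H]1CN2C(=O)C=C(c3ccc(NS(C)(=O)=O)cc3)CC2[C@@H]1c1ccc(F)cc1)c1cc(C(F)(F)F)cc(C(F)(F)F)c1` share one core and differ only on its double-bonded ring carbon. In an assay on CHO cells for displacement of a labelled ligand from Substance-P receptor (Homo sapiens) (on this read-out higher numbers stand for weaker inhibition and lower numbers for stronger inhibition), compound 1 gives 0.93 nM. In this assay compound 2 gives 1 nM, and the step of a 1.1-fold higher number from compound 1 to compound 2 (0.03 log units; within the scatter) shows the two compounds sit within the scatter of each other; compound 2 is the later of the two numbers, not a separate level. Compound 3 `C[C@@H](O[C@H]1CN2C(=O)C=C(c3ccncc3)CC2[C@@H]1c1ccc(F)cc1)c1cc(C(F)(F)F)cc(C(F)(F)F)c1` is not yet measured; it differs from compound 2 by pyridin-4-yl in place of 4-(methanesulfonamido)phenyl on a double-bonded ring carbon. Among the compounds with values here, the only measured step that bears on this position, from compound 1 to compound 2, left the number essentially unchanged, so a second swap of the aromatic ring at this carbon is expected to stay near that level, with the step of a 1.5-fold higher number from compound 2 to compound 3 (0.18 log units; within the scatter) expected to be small and of uncertain direction. Compound 3 is therefore expected to give about 1.5 nM in this assay, between 0.5 nM and 6 nM.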

Compound 3, half-maximal inhibitory concentration: 0.14 nM
Beside the measured number, compound 3's estimate is 11-fold (1.03 log units) above it; measured number outside the range, below it.
By their numbers in this assay, from the lowest: compound 3; then compounds 1 and 2 (each within the scatter of the next).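

In this assay the double-bonded ring carbon proves sensitive to the aromatic ring it carries, with a 7.1-fold lower number from compound 2 to compound 3 (0.85 log units; beyond the scatter) and a 6.6-fold lower number from compound 1 to compound 3 (0.82 log units; beyond the scatter) when pyridin-4-yl enters. The earlier swap had added methanesulfonamido to the phenyl ring without moving the number beyond the scatter, whereas replacing a carbon-only aromatic ring with one that holds a hetero atom does move it, and compound 3 is the most potent of the three. No measurement given here bears on why pyridin-4-yl lowers the number. The compounds shown leave open whether the location of the ring nitrogen matters, as pyridin-3-yl or pyridin-2-yl would test. They also leave open whether a second ring nitrogen, as in pyrimidin-5-yl, or an amino group on the pyridine ring would keep the step.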